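Methylating the pyrazole of a potent kinase binder

A few compounds are considered here, and "the series" means these few. Any claim that something is new, unique, unknown or untested is made for them only; others in the source may bear on it.

Measured compounds:
- compound 1, `CN(C)c1c(C#N)c2c(N)ncnc2n1C`, 259 nM
- compound 2, `Cn1c(NCc2ccccc2F)c(C#N)c2c(N)ncnc21`, 120 nM
- compound 3, `Cc1n[nH]cc1Nc1nc(N)c2c(C#N)c(N3CCC[C@H]3C)n(C)c2n1`, 2 nM

In an assay on isolated protein for binding affinity to Leucine-rich repeat serine/threonine-protein kinase 2 variant G2019S (Homo sapiens), read by TR-FRET and LanthaScreen, with a stated time of 2 h (on this read-out lower numbers stand for stronger inhibition and higher numbers for weaker inhibition), compound 3 gives the lowest of the three numbers. Compound 2 stands nearest to it, and compound 1 furthest away; both gaps lie beyond the usual scatter, so compound 3 counts as the most potent of the measured set.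

The unmeasured compound 4, `Cc1c(Nc2nc(N)c3c(C#N)c(N4CCC[C@H]4C)n(C)c3n2)cnn1C`, differs from compound 3 at a single place: 1,5-dimethyl-1H-pyrazol-4-yl in place of 3-methyl-1H-pyrazol-4-yl on a nitrogen on an aromatic ring. The group that leaves carries the one hydrogen-bond donor of that ring; the group that enters has none and brings a second acceptor instead.

Going by the values given here, no measured pair shows this change, so the step has to be estimated. Across the set, only the wider contrast between compound 3 and the other two is known. The expected step from compound 3 to compound 4 in this assay is a 2.0-fold higher number from compound 3 to compound 4 (0.30 log units; within the scatter), a small rise that may sit within the scatter. Compound 4 is expected to give 4 nM, with a range from 1.5 nM to 15 nM.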

Compound 4, inhibition constant: 3 nM
Beside the measured number, compound 4's estimate is 1.3-fold (0.12 log units) above it, within the range that was stated.
By their numbers in this assay, from the lowest: compounds 3 and 4 (each within the scatter of the next); then compound 2; then compound 1.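

Exchanging 3-methyl-1H-pyrazol-4-yl for 1,5-dimethyl-1H-pyrazol-4-yl on a nitrogen on an aromatic ring gives, in this assay, a 1.5-fold higher number from compound 3 to compound 4 (0.18 log units; within the scatter), so the change cannot be separated from the scatter. Going by these compounds alone, the group that leaves has 1 hydrogen-bond donor and the group that enters has 0, so at this place the donor can go without a measurable loss, something no earlier pair could show. Nothing available explains why the number holds across this change.

The compounds shown do not tell how much each methyl group of the entering ring contributes, which a 1-methyl-1H-pyrazol-4-yl group would address. They also leave open whether this place accepts a larger substituent on the ring nitrogen, such as a 2-hydroxyethyl chain or a piperidine.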